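A few compounds are considered here, and "the series" means these few. Any claim that something is new, unique, unknown or untested is made for them only; others in the source may bear on it.

Of the compounds shown here, three have so far been measured in an ADME assay on BEAS-2B cells (Homo sapiens) for cytotoxicity, read by MTT assay, with a stated time of 72 h; on this read-out lower numbers stand for stronger inhibition of growth and higher numbers for weaker inhibition of growth. Compound 1, `CC(C)COC(=O)Nc1ccc([Se][Se]c2ccc(NC(=O)OCC(C)C)cc2)cc1`, gives 42700 nM in this assay. Compound 3, `CCOC(=O)Nc1ccc([Se][Se]c2ccc(NC(=O)OCC)cc2)cc1`, gives 44000 nM. Compound 2, `CCCOC(=O)Nc1ccc([Se]C#N)cc1`, gives 46300 nM; its number lies within the usual scatter of both compound 1 and compound 3, so the three compounds cannot be told apart on this read-out, and compound 2 stands together with the others rather than apart from them.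

Compound 4, `CC(C)COC(=O)Nc1ccc([Se]C#N)cc1`, has not yet been measured. It differs from compound 2 by methyl in place of hydrogen on a saturated chain carbon bound to two saturated chain carbons. Among the compounds with values here, no step between two measured compounds isolates this change, so nothing measured speaks directly for it. What the data do show is that all three measured compounds, which differ in their carbamate chains, give numbers within the scatter of one another. The expected step of a 1.0-fold lower number from compound 2 to compound 4 (0.01 log units; within the scatter) is therefore none beyond the scatter, in neither direction. Compound 4 is estimated at 45000 nM, with a range from 22000 nM to 90000 nM.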

Compound 4, concentration for total growth inhibition: 49500 nM
The estimate for compound 4 lay 1.1-fold (0.04 log units) below the measured number; measured number inside the range.
By their numbers in this assay, from the lowest: compounds 1, 3, 2 and 4 (each within the scatter of the next).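

Within the data shown here, for the first time, two measured compounds differ only by methyl in place of hydrogen on a saturated chain carbon bound to two saturated chain carbons, and this propyl to isobutyl change gives a 1.1-fold higher number from compound 2 to compound 4 (0.03 log units; within the scatter) in this assay on this shared core. At this position, then, the added methyl does not separate the two compounds on this read-out, and this now rests on a direct pair rather than on a comparison of compounds that differ in more than one place. Nothing measured here offers an explanation for this result.

The compounds shown leave open whether a longer chain, a phenyl ring or an amine on this carbon would give a step beyond the scatter. They also leave open whether the same methyl change would give a similar step on the core of compound 1.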